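Dichlorophenyl for trimethylphenyl: expected effect on receptor binding

The source may report more compounds than this note shows. Statements on the series, on what has been measured and on what is new or still open speak of the compounds shown alone.

Measured so far:
- compound 1 `Cc1cc(-c2c(O)nc3cc(Cl)c(C(=O)Nc4ccncn4)cc3c2OCC[C@@H]2CCCCN2)cc(C)c1C`: 0.3 nM
- compound 2 `Cc1cc(C)cc(-c2c(O)nc3cc(Cl)c(NC(=O)c4cnccn4)cc3c2OCCC2CCCCN2)c1`: 10 nM

In an assay on isolated protein for inhibition of Gonadotropin-releasing hormone receptor (Homo sapiens) (a higher number here means a weaker inhibitor, a lower number a stronger inhibitor), compound 1 gives 0.3 nM, the lowest number of the two. Among the measured compounds shown here, compound 2 gives 10 nM, a higher number that lies beyond the scatter; the two structures differ in more than one place, so no single step is drawn between them.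

Compound 3 `O=C(Nc1ccncn1)c1cc2c(OCC[C@@H]3CCCCN3)c(-c3cc(Cl)cc(Cl)c3)c(O)nc2cc1Cl` has not yet been measured. Its change from compound 1 is 3,5-dichlorophenyl in place of 3,4,5-trimethylphenyl on an aromatic carbon, a 3,5-dichlorophenyl in place of 3,4,5-trimethylphenyl on an aromatic carbon of the shared core. For the measured compounds named here, no measured pair shows this change, so the size of the step is open. A modest rise in the number, at or just beyond the scatter, is expected for compound 3 from a 3.3-fold higher number from compound 1 to compound 3 (0.52 log units; beyond the scatter). Compound 3 is estimated at 1 nM, with a range from 0.2 nM to 5 nM.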

Compound 3, half-maximal inhibitory concentration: 1.1 nM
The estimate for compound 3 lay 1.1-fold (0.04 log units) below the measured number; measured number inside the range.
By their numbers in this assay, from the lowest: compound 1; then compound 3; then compound 2.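

In this assay, among the compounds shown here, 3,5-dichlorophenyl in place of 3,4,5-trimethylphenyl on this aromatic carbon, ortho to the 2-(piperidin-2-yl)ethoxy group and to the hydroxy group, gives a 3.7-fold higher number from compound 1 to compound 3 (0.56 log units; beyond the scatter), the first step that differs in one place only. This modest step, beyond the scatter, shows that the position accepts an aryl group with chlorine in place of methyl while compound 3 keeps a low number, 1.1 nM. Nothing available explains the size of this step.

For the compounds shown here, the single step changes both the kind and the count of the ring substituents, so the effect of replacing methyl with chlorine cannot be separated from that of losing the third methyl. Unsubstituted phenyl and 3,5-difluorophenyl at this position on the same core would help to separate those two changes.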